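The compounds below may be only part of what the source reports. "The series", "measured", "known", "first", "only" and "open" are said of these compounds alone.

Compound 2 `O=C(NC(=S)N1CCc2c(OCCCCCOc3ccc(Cl)cc3)cccc21)c1ccoc1` carries a five-membered aromatic ring on the carbonyl carbon of its shared core. In an ADME assay on Huh-7 cells (Homo sapiens) for cytotoxicity (a lower number here means that less compound is tolerated, a higher number that more compound is tolerated), compound 2 gives 20100 nM. This is the highest of the two numbers available, though only by a little: its nearest neighbour is compound 1 `O=C(NC(=S)N1CCc2c(OCCCCCOc3ccc(Cl)cc3)cccc21)c1ccc([N+](=O)[O-])cc1`, which in this assay gives 13600 nM. The change a 1.5-fold higher number from compound 1 to compound 2 (0.17 log units; within the scatter) replaced a 4-nitrophenyl group with a furan-3-yl group on the same carbonyl carbon, and the two compounds cannot be told apart on these numbers.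

Compound 3 `O=C(NC(=S)N1CCc2c(OCCCCCOc3ccc(Cl)cc3)cccc21)c1ccsc1` is the next step. The difference from compound 2 is thiophen-3-yl in place of furan-3-yl on a carbonyl carbon. Within the data shown here, no measured pair shows exactly this exchange, so the only guide is the step from compound 1 to compound 2, which changed the group on this carbonyl carbon more drastically and still stayed inside the scatter. A swap of one five-membered ring for a closely related one is therefore expected to give a step of a 1.1-fold lower number from compound 2 to compound 3 (0.02 log units; within the scatter), in no particular direction beyond the scatter. For compound 3 the estimate in this assay is 19000 nM, with a range from 9000 nM to 40000 nM.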

Compound 3, half-maximal cytotoxic concentration: > 50000 nM
Compound 3 gave a limit, no number (the forecaster's own chance of this, stated with the estimate: 15%); middle value at least 2.6-fold (0.42 log units) from the limit.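

In this assay, the group on this carbonyl carbon can make a difference after all: thiophen-3-yl in place of furan-3-yl gives an at least 2.4-fold higher number from compound 2 to compound 3 (0.39 log units; beyond the scatter), whereas the step between the two earlier compounds stayed within the scatter. Thiophen-3-yl also stands apart from 4-nitrophenyl, with an at least 3.6-fold higher number from compound 1 to compound 3 (0.56 log units; beyond the scatter), so a change from oxygen to sulfur in a five-membered aromatic ring, with the same count of heavy atoms, separates compounds here more clearly than the much larger exchange of 4-nitrophenyl for furan-3-yl did. The reading for compound 3 is a limit of the assay and not a number, so both steps give only a smallest size: the limit of > 50000 nM in this assay, at which 1 of the 3 values shown sits.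

Going by these compounds, what the sulfur atom contributes remains open, and the attachment point matters too: a thiophen-2-yl group on the same carbonyl carbon would show whether the result belongs to thiophen-3-yl alone. All the compounds shown carry an aromatic ring at this place, so what a cyclohexyl ring, a simple methyl group or a chain ending in an amine would do there cannot be told.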